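The source may hold more compounds than are shown below. What is called first, only, known or untested is meant among the compounds shown, and "the series" means these compounds.

Compound 3 `COc1cc(/C=C/C(=O)c2ccc(OCCCSC(=S)N3CCCC3)cc2)cc(OC)c1OC` gives 11100 nM in a functional assay on ECa-109 cells for inhibition, with ECa-109 cell line (Homo sapiens) as the target, read by MTT assay, with a stated time of 72 h (on this read-out lower numbers stand for stronger inhibition and higher numbers for weaker inhibition), the second highest of the three numbers measured. Compound 2 `COc1cc(/C=C/C(=O)c2ccc(OCCCSC(=S)N3CCN(C)CC3)cc2)cc(OC)c1OC` gives 7430 nM in this assay. For the measured compounds named here, the only single-point step measured, a 1.5-fold higher number from compound 2 to compound 3 (0.17 log units; within the scatter), stays within the scatter. Compound 1 `O=C(/C=C/c1cccs1)c1ccc(OCCSC(=S)N2CCCC2)cc1` gives 18300 nM in this assay, and its value and that of compound 3 lie within the scatter of each other. Compound 4 `COc1cc(/C=C/C(=O)c2ccc(OCCSC(=S)N3CCCC3)cc2)cc(OC)c1OC` differs from compound 3 by a group of 8 heavy atoms (5 carbon, 1 nitrogen, 2 sulfur; one five-membered non-aromatic ring with 1 hetero atom) in place of a group of 9 heavy atoms (6 carbon, 1 nitrogen, 2 sulfur; one five-membered non-aromatic ring with 1 hetero atom), on a saturated chain carbon, two bonds along the chain from an oxygen on an aromatic ring. Going by the values given here, no measured step changes this chain alone, since compound 1 carries the shorter chain but also a different aromatic ring, so no direction can be read from the data. Compound 4 is therefore expected to give 11000 nM in this assay, between 4000 nM and 30000 nM. The expected step of a 1.0-fold lower number from compound 3 to compound 4 (0.00 log units; within the scatter) stays within the scatter.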

Compound 4, half-maximal inhibitory concentration: 10700 nM
Compound 4: middle estimate off by 1.0-fold (0.01 log units), on the high side; the measured number falls inside the stated range.
By their numbers in this assay, from the lowest: compounds 2, 4, 3 and 1 (each within the scatter of the next, the first and the last beyond it).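

For the compounds shown here, the step of a 1.0-fold lower number from compound 3 to compound 4 (0.02 log units; within the scatter) is the first measured change of this chain alone, and in this assay the group of 8 heavy atoms in place of the group of 9 heavy atoms stays within the scatter. The step of a 1.4-fold higher number from compound 2 to compound 4 (0.16 log units; within the scatter), which also exchanges the six-membered ring for the five-membered one, stays within the scatter as well. Nothing measured beyond these numbers bears on this result. From the compounds shown here alone, whether a longer chain, or a morpholine ring on the thiocarbonyl carbon, would move the number beyond the scatter remains open.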